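The source may report more compounds than this note shows. Statements on the series, on what has been measured and on what is new or still open speak of the compounds shown alone.

Compound 3 `O=C(CN1CCN(c2ccc([N+](=O)[O-])cc2)CC1)C(O)(c1ccccc1)C1CCC1` stands at the edge of what was measured: in a functional assay on ileum for antagonist activity at muscarinic acetylcholine receptor M3 (Cavia porcellus) (a higher number here means a weaker inhibitor, a lower number a stronger inhibitor), compound 3 gives > 10000 nM, which is a limit of the assay and not a number. Compound 2 `CCOc1ccccc1N1CCN(CC(=O)C(O)(c2ccccc2)C2CCC2)CC1` likewise gives only a limit in this assay, > 10000 nM. Among the compounds with values here, the one numeric value belongs to compound 1 `O=C(CN1CCN(C/C=C\c2ccccc2)CC1)C(O)(c1ccccc1)C1CCC1`, which gives 9.92 nM in this assay, so that an at least 1000-fold higher number from compound 1 to compound 2 (3.00 log units; beyond the scatter) and an at least 1000-fold higher number from compound 1 to compound 3 (3.00 log units; beyond the scatter) are both read against (the limit of > 10000 nM in this assay, at which 2 of the 3 values shown sit). Between compound 2 and compound 3 the step is a step that the two limits leave unreadable from compound 2 to compound 3.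

Compound 4 `CC(C)=CCN1CCN(CC(=O)C(O)(c2ccccc2)C2CCC2)CC1` differs from compound 3 in one place: 3-methylbut-2-en-1-yl in place of 4-nitrophenyl on an amine nitrogen in a ring. Within the data shown here, the step that bears on it is the one from compound 1 to compound 3, where an aryl group replaced an alkenyl chain on that ring nitrogen and the number rose beyond the scatter; compound 4 restores an alkenyl chain, shorter than the one in compound 1. The step from compound 3 to compound 4 in this assay is therefore expected to be an at least 330-fold lower number from compound 3 to compound 4 (2.52 log units; beyond the scatter), a return toward compound 1. Compound 4 is estimated to give 30 nM in this assay, between 5 nM and 300 nM.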

Compound 4, antagonist equilibrium constant: 22 nM
Compound 4: middle estimate off by 1.4-fold (0.13 log units), on the high side; the measured number falls inside the stated range.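

In this assay, placing 3-methylbut-2-en-1-yl on the ring nitrogen gives an at least 450-fold lower number from compound 3 to compound 4 (2.65 log units; beyond the scatter) and an at least 450-fold lower number from compound 2 to compound 4 (2.65 log units; beyond the scatter), so the low number at this position is not tied to the longer chain of compound 1. Replacing 2-phenylethenyl with 2-methylprop-1-en-1-yl on the saturated chain carbon gives a 2.2-fold higher number from compound 1 to compound 4 (0.35 log units; beyond the scatter), a modest step that shows that a phenyl ring in this chain is not needed for a low number. The two larger steps are read against a limit, not against a number: the limit of > 10000 nM in this assay, at which 2 of the 4 values shown sit.

As far as these compounds go, what a saturated chain such as 3-methylbutyl would give on this nitrogen stays open, so the part played by the double bond cannot be told. Also open, from the compounds shown here alone, is whether benzyl, which carries its phenyl ring on a single carbon, would behave like the alkenyl chains or like the aryl groups.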